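Swapping the pyrimidine for a hydroxypyridine on the amide

The source may hold more compounds than are shown below. What is called first, only, known or untested is meant among the compounds shown, and "the series" means these compounds.

Compound 2 `O=C(Nc1ccc(Cl)cc1CN1C(=O)c2ccccc2C1=O)c1ncccn1` carries a pyrimidin-2-yl group on the carbonyl carbon of the amide. In an assay on CHO cells for positive allosteric modulation of metabotropic glutamate receptor 5 (Rattus norvegicus), read by FLIPR (on this read-out higher numbers stand for an effect only at larger amounts of compound and lower numbers for an effect already at smaller amounts), compound 2 reaches only a limit of the assay, < 1000 nM, not a measured number. Going by the values given here, its one close neighbour is compound 1 `O=C(Nc1ccc(Cl)cc1CN1C(=O)c2ccccc2C1=O)c1ccco1`, which bears a furan-2-yl group in the same place. In this assay compound 1 likewise stops at a limit, < 1000 nM. The step that the two limits leave unreadable from compound 1 to compound 2 therefore cannot be sized, since the limit of < 1000 nM in this assay, at which 2 of the 2 values shown sit, is all that either compound shows.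

Compound 3 `O=C(Nc1ccc(Cl)cc1CN1C(=O)c2ccccc2C1=O)c1ncccc1O` changes the group once more: 3-hydroxypyridin-2-yl in place of pyrimidin-2-yl on a carbonyl carbon. Among the compounds with values here, no measured step bears on this change, so its direction and size cannot be read from the data. Because the limit of < 1000 nM in this assay, at which 2 of the 2 values shown sit, is where both neighbours sit, the expectation is that compound 3 stays in the same region, and the step that the limit leaves unreadable from compound 2 to compound 3 is estimated to lie within the usual scatter. The estimate for compound 3 in this assay is 300 nM, with a range from 50 nM to 1500 nM, and a fair chance that only a limit is again reported.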

Compound 3, half-maximal effective concentration: < 1000 nM
Compound 3: a limit, no number; the forecaster's own chance of this, stated with the estimate: 55%; the middle value is on the limit's open side.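

Going by these compounds alone, compound 3 also gives only a limit and not a number, so no step among compound 1, compound 2 and compound 3 can be read, and all three stop at the same point: the limit of < 1000 nM in this assay, at which 3 of the 3 values shown sit.

From the compounds shown here alone, how far apart these compounds really lie in this assay remains open, as does whether furan-2-yl, pyrimidin-2-yl or 3-hydroxypyridin-2-yl on the carbonyl carbon makes any difference.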